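The source may report more compounds than this note shows. Statements on the series, on what has been measured and on what is new or still open speak of the compounds shown alone.

Of the compounds shown here, three sharing one core have been measured in a functional assay for inhibition, with Homo sapiens as the target; on this read-out lower numbers stand for tighter binding and higher numbers for weaker binding. There, compound 1 `O=C(O)CC/C=C\CC1COC(c2ccc(C(F)(F)F)cc2)OC1c1cccnc1` gives 1780 nM, compound 2 `O=C(O)CC/C=C\CC1COC(c2cccnc2)OC1c1cccnc1` gives 759 nM, and compound 3 `O=C(O)CC/C=C\CC1COC(c2ccsc2)OC1c1cccnc1` gives 1580 nM. The standing of compound 3 comes from two comparisons: the data show a 1.1-fold lower number from compound 1 to compound 3 (0.05 log units; within the scatter), and they also show a 2.1-fold higher number from compound 2 to compound 3 (0.32 log units; beyond the scatter).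

The next compound, compound 4 `O=C(O)CC/C=C\CC1COC(c2ccco2)OC1c1cccnc1`, keeps the shared core and has furan-2-yl in place of thiophen-3-yl on a saturated ring carbon, (furan-2-yl in place of thiophen-3-yl on a saturated ring carbon). All three measured steps changed the group on this same carbon. Within the data shown here, the largest of them is modest, at a 2.3-fold lower number from compound 1 to compound 2 (0.37 log units; beyond the scatter), but none of the measured compounds carries furan-2-yl. One five-membered aromatic ring with 1 hetero atom replaces another, so in this assay the expectation is a small step, probably none beyond the scatter and with no firm direction. That expectation amounts to an estimated 1.2-fold lower number from compound 3 to compound 4 (0.08 log units; within the scatter). Compound 4 is estimated at 1300 nM, with an expected range of 650 nM to 2600 nM.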

Compound 4, dissociation constant: 1260 nM
Beside the measured number, compound 4's estimate is 1.0-fold (0.01 log units) above it; low and high end bracket the measured number.
By their numbers in this assay, from the lowest: compounds 2, 4, 3 and 1 (each within the scatter of the next, the first and the last beyond it).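

Furan-2-yl, on the carbon between two ring oxygen atoms, lies within the scatter of all three other groups in this assay: the data show a 1.3-fold lower number from compound 3 to compound 4 (0.10 log units; within the scatter) and a 1.7-fold higher number from compound 2 to compound 4 (0.22 log units; within the scatter) and also a 1.4-fold lower number from compound 1 to compound 4 (0.15 log units; within the scatter). Oxygen in place of sulfur in the five-membered aromatic ring, together with a different point of attachment, therefore gives no step beyond the scatter, and furan-2-yl cannot be placed on either side of the modest gap between pyridin-3-yl and the other two groups. No outside measurement helps to explain these numbers.

Thiophen-2-yl and furan-3-yl would separate the ring atom from the point of attachment, which this step changes together. On these data alone, it also remains open how a non-aromatic group such as cyclohexyl would fare on this carbon.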